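Halogen swap on the 4-chlorophenyl group of compound 2

The source may report more compounds than this note shows. Statements on the series, on what has been measured and on what is new or still open speak of the compounds shown alone.

Measured in a functional assay on HT-29 cells (Homo sapiens) for antiproliferative activity, read by sulforhodamine B assay, with a stated time of 72 h; a higher number here means a weaker inhibitor, a lower number a stronger inhibitor:
- compound 1 `N#Cc1ccc(NC(=S)N/N=C/c2ccc3ccccc3n2)cc1`: 15600 nM
- compound 2 `S=C(N/N=C/c1ccc2ccccc2n1)Nc1ccc(Cl)cc1`: 97200 nM

Of the two, compound 2 carries the higher number, at 97200 nM. Compound 3 `S=C(N/N=C/c1ccc2ccccc2n1)Nc1ccc(Br)cc1` has not yet been measured. It differs from compound 2 by bromo in place of chloro on an aromatic carbon. Within the data shown here, the only measured step, a 6.2-fold higher number from compound 1 to compound 2 (0.79 log units; beyond the scatter), is modest but beyond the scatter, and it put chloro in place of cyano. Among the measured compounds shown here, no halogen-for-halogen step has been measured, so that step serves only as a loose upper guide. The expected step is a 1.2-fold lower number from compound 2 to compound 3 (0.08 log units; within the scatter), with no change beyond the scatter anticipated in this assay. Compound 3 is estimated at 80000 nM, with an expected range of 32000 nM to 190000 nM.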

Compound 3, half-maximal inhibitory concentration: 54400 nM
Estimate against measurement, compound 3: 1.5-fold (0.17 log units) above; measured number inside the range.
By their numbers in this assay, from the lowest: compound 1; then compounds 3 and 2 (each within the scatter of the next).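

In this assay, among these compounds, the first halogen-for-halogen exchange at this position gives a 1.8-fold lower number from compound 2 to compound 3 (0.25 log units; within the scatter) and so does not separate 4-chlorophenyl from 4-bromophenyl. Replacing the nitrile with bromo gives a 3.5-fold higher number from compound 1 to compound 3 (0.54 log units; beyond the scatter) and repeats, with a second halogen, the direction already seen with chloro. Among these three compounds, the nitrile stands apart from both halogens.

Going by these compounds, whether an amine, a carboxylic acid or a methoxy group here would fall with the nitrile, with the halogens or elsewhere remains open. No available evidence accounts for these steps.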